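The compounds below may be only part of what the source reports. "The series", "measured", "known", "first", "only" and "open" are said of these compounds alone.

In a functional assay on CCRF-CEM cells (Homo sapiens) for inhibition (on this read-out lower numbers stand for stronger inhibition and higher numbers for weaker inhibition), compound 1 (`Nc1nc(O)c2ncn([C@@H]3O[C@@H](CO)C=C3F)c2n1`) gives > 100000 nM as a limit of the assay and not a number. Compound 2 (`Nc1nc(Cl)c2ncn([C@H]3O[C@@H](CO)C=C3F)c2n1`) gives > 100000 nM as a limit too. Compound 3 (`Nc1nc(O)c2ncn([C@H]3O[C@@H](CO)C=C3F)c2n1`) gives > 100000 nM as a limit as well, so it stands without a true number.

Compound 4 (`OC[C@H]1C=C(F)[C@@H](n2cnc3c(O)ncnc32)O1`) differs from compound 3 in one place on the shared core (hydrogen in place of amino on an aromatic carbon): hydrogen in place of amino on an aromatic carbon, between two ring nitrogen atoms.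

Within the data shown here, two measured steps touch compound 3. One is a step that the two limits leave unreadable from compound 1 to compound 3 and concerns configuration only, as the fact that compounds 1 and 3 differ only in the configuration as drawn shows. The other is a step that the two limits leave unreadable from compound 2 to compound 3 with hydroxy in place of chloro on an aromatic carbon. Among the measured compounds shown here, neither has a readable size and neither involves the amino group, so no measured step speaks directly to this change. For the measured compounds named here, what the series does offer is the limit of > 100000 nM in this assay, at which 3 of the 3 values shown sit, and no compound in it gives a number to build on.

The expectation therefore rests on compound 3 and its limit of > 100000 nM as the starting point. The expected outcome is a number no higher from compound 3 to compound 4 (the limit leaves the size open) with no clear direction and nothing beyond the usual scatter, and another limit is the likeliest report. Compound 4 is estimated at 100000 nM with an expected range (40000 nM to 250000 nM).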

Compound 4, half-maximal inhibitory concentration: > 100000 nM
Compound 4 was reported as a limit; the forecaster's own chance of this, stated with the estimate: 85%; the middle value sits exactly at the limit.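

In this assay compound 4 gives > 100000 nM, which is a limit of the assay and not a number. Compound 3 also stands only as a limit, so the step from compound 3 to compound 4 cannot be read. The compounds shown leave open whether any change on the shared core would shift this read-out, because none of them gives a true number: the limit of > 100000 nM in this assay, at which 4 of the 4 values shown sit.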